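The compounds below may be only part of what the source reports. "The series", "measured", "known", "first", "only" and "open" are said of these compounds alone.

Two compounds of this series have a number in an ADME assay on microsomes from liver (Rattus norvegicus) for metabolic stability, with a stated time of 10 min; a lower number here means that less of the compound is left, a higher number that more of the compound is left. Compound 1, `CC(C)NCCS(=O)(=O)NC(=O)c1ccc(Nc2nc(NC3(c4ccc(Cl)cc4)CC3)nc(OCC(F)(F)F)n2)cc1`, is the one that stays closest to intact: in this assay compound 1 gives 100%, the highest of the two numbers. Compound 2, `CCCCCNc1nc(Nc2ccc([N+](=O)[O-])cc2)nc(OCC(F)(F)F)n1`, shares only part of its build with compound 1, and in this assay compound 2 gives 35%, a number that lies well beyond the usual scatter below that of compound 1. Among the measured compounds shown here, no single-point step between measured compounds has been recorded, so there is no measured step from which a change at the amine nitrogen could be read.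

Compound 3, `CC(C)C(=O)NCCS(=O)(=O)NC(=O)c1ccc(Nc2nc(NC3(c4ccc(Cl)cc4)CC3)nc(OCC(F)(F)F)n2)cc1`, has not yet been run in this assay. It differs from compound 1 in one place: isopropylcarbonyl in place of isopropyl on an amine nitrogen. The amine becomes an amide; the rest of compound 1, including the shared core, is kept. For the measured compounds named here, with no measured pair to lean on, the expectation rests on the high number of compound 1 alone: the step is expected to be none beyond the scatter, downward if at all, as a number 8 percentage points lower from compound 1 to compound 3 (within the scatter) expresses. Compound 3 is therefore estimated at 92%, within a range from 75% to 100%.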

Compound 3, percent of the compound remaining: 84%
For compound 3 the middle estimate is 8 percentage points above the measured one; measured number inside the range.
By their numbers in this assay, from the lowest: compound 2; then compound 3; then compound 1.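

Among the compounds shown here, this is the only step so far that changes a single place, so it gives the first direct reading at this amine nitrogen. Within this assay the replacement of isopropyl by isopropylcarbonyl, which turns the amine into an amide, gives a number 16 percentage points lower from compound 1 to compound 3 (beyond the scatter) with the rest of the structure unchanged. The step is modest but lies beyond the usual scatter, so what sits on this nitrogen does affect the number, and since nothing else differs between the two compounds, the difference can be traced to this one change, although no available evidence explains how it arises.

The compounds shown leave open whether the step comes from the carbonyl itself or from the carbonyl together with its isopropyl, a question that an acetyl, a cyclopropylcarbonyl or a methyl sulfonyl group on the same nitrogen could help to answer. They also leave open whether a primary amine or a carboxylic acid at the end of this chain would keep the number close to that of compound 1 or move it further down.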